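Replacing pyridin-3-yl with thiophen-2-yl in compound 3

The compounds below may be only part of what the source reports. "The series", "measured", "known", "first", "only" and "open" are said of these compounds alone.

Three compounds have been examined in an ADME assay on A549 cells (Homo sapiens) for cytotoxicity, read by MTT assay, with a stated time of 72 h (on this read-out higher numbers stand for weaker inhibition and lower numbers for stronger inhibition), and only one of them gives a number. Compound 1 (`O=C1Nc2ccc([N+](=O)[O-])cc2/C1=C\c1ccccn1`) is reported as ("not toxic" (no number reported)), with no figure attached. Compound 2 (`Cc1ccc(C(=O)CC2(O)C(=O)Nc3ccc(Nc4ccco4)cc32)cc1`) is recorded at > 100000 nM as a limit of the assay and not a number. Compound 3 (`O=C1Nc2ccc(Br)cc2C1=Cc1cccnc1`) gives 31400 nM as the sole numerical result, so it is the only firm reference point in the set.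

Compound 4 (`O=C1Nc2ccc(Br)cc2C1=Cc1cccs1`) has not yet been tested. It carries thiophen-2-yl in place of pyridin-3-yl on a double-bonded chain carbon bound to a double-bonded ring carbon. Among the measured compounds shown here, no measured pair in the set shows what such an exchange does, so the expectation rests on the single value of compound 3 (31400 nM) and remains loose. In this assay a modest shift towards stronger inhibition is expected, of a size close to the usual scatter. The estimated change (a 1.6-fold lower number from compound 3 to compound 4 (0.20 log units; within the scatter)) is therefore small and uncertain in direction. For compound 4 the expected value is 20000 nM within an estimated range from 6000 nM to 65000 nM in this series.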

Compound 4, half-maximal inhibitory concentration: 427000 nM
Compound 4: middle estimate off by 21-fold (1.33 log units), on the low side; measured number outside the range, above it.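

At this place, on a double-bonded chain carbon bound to a double-bonded ring carbon, exchanging pyridin-3-yl for thiophen-2-yl in this assay gives a 14-fold higher number from compound 3 to compound 4 (1.13 log units; beyond the scatter). Among the compounds shown here, this is the first change in the set that can be read, and it shows that this one group can move the number well beyond the usual scatter, towards weaker inhibition, while the rest of the structure stays the same. Compound 2 is recorded only as a limit and not a number, and it differs from the other compounds in more than one place, so it adds nothing to this step: the limit of > 100000 nM in this assay, at which 1 of the 4 values shown sits.

A single step cannot separate the contributions of the ring size and of the exchange of nitrogen for sulfur, and it cannot show whether the same exchange would have a similar effect on another core. On these data alone, it also remains open whether a plain phenyl ring, or a pyridine ring carrying an amine, at the same place would give a number nearer that of compound 3 or that of compound 4.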